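This account rests on a few compounds, and the source may have more. Where it says the series, first, only, none or still open, it means among the compounds named here.

Compounds measured so far:
Compound 1, `CC(=O)Oc1ccccc1C(=O)O[C@H]1CO[C@H]2[C@@H]1OC[C@H]2OC(=O)c1ccnn1C`, gives 0.0642 h in an ADME assay on a cell-free system (plasma, Homo sapiens) for metabolic stability, with Plasma (Rattus norvegicus) as the target, read by HPLC, at pH 7.4; on this read-out higher numbers stand for a longer-lived compound and lower numbers for a shorter-lived compound.
Compound 2, `CC(=O)Oc1ccccc1C(=O)O[C@H]1CO[C@H]2[C@@H]1OC[C@H]2OC(=O)c1ccccc1C`, gives 0.0138 h in this assay.

For the measured compounds named here, compound 2 stands at the lowest of the two numbers, its nearest neighbour being compound 1, and the single measured step, a 4.7-fold lower number from compound 1 to compound 2 (0.67 log units; beyond the scatter), is what separates them. That step exchanges the whole aromatic unit on the carbonyl carbon, so it does not speak directly to the smaller change now at hand.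

Compound 3, `COc1ccccc1C(=O)O[C@@H]1CO[C@H]2[C@@H]1OC[C@@H]2OC(=O)c1ccccc1OC(C)=O`, differs from compound 2 by methoxy in place of methyl on an aromatic carbon. The group enters on an aromatic carbon of a six-membered aromatic ring of carbon only, ortho to a large group, and the same difference cut one bond further out reads (2-methylphenyl)carbonyl to (2-methoxyphenyl)carbonyl. Going by the values given here, no measured pair in this set compares methoxy with methyl, so the data give no calibrated guide to the size of this step in this assay; the only comparison available, a 4.7-fold lower number from compound 1 to compound 2 (0.67 log units; beyond the scatter), concerns a different change.

It is therefore expected that compound 3 sits close to compound 2, with a step of a 1.3-fold higher number from compound 2 to compound 3 (0.12 log units; within the scatter) that should not exceed the scatter. The estimated half-life for compound 3 is 0.018 h, within a range from 0.006 h to 0.05 h.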

Compound 3, half-life: 0.0165 h
Compound 3: the middle estimate sits 1.1-fold (0.04 log units) above what was measured, within the range that was stated.
By their numbers in this assay, from the lowest: compounds 2 and 3 (each within the scatter of the next); then compound 1.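

In this assay, for the compounds shown here, methoxy in place of methyl on an aromatic carbon, ortho to a large group, gives a 1.2-fold higher number from compound 2 to compound 3 (0.08 log units; within the scatter) and so leaves the half-life indistinguishable, which the earlier compounds could not show, since they offered no change confined to this one group. The exchange of the whole aromatic unit on the carbonyl carbon now has a second reading, a 3.9-fold lower number from compound 1 to compound 3 (0.59 log units; beyond the scatter), which runs the same way as a 4.7-fold lower number from compound 1 to compound 2 (0.67 log units; beyond the scatter), so the gap to compound 1 holds with either group on the phenyl ring. Nothing available explains either the flat step or this gap.

From the compounds shown here alone, the two groups compared here are small and neutral, so it remains open whether an amine, a carboxylic acid or a longer chain such as butoxy in the same place would also stay within the scatter of compound 2. Going by these compounds, it is equally open whether the gap to compound 1 belongs to the 1-methyl-1H-pyrazol-5-yl unit alone, or whether another unit on the carbonyl carbon, such as a pyridine ring or a saturated cyclohexyl ring, would give a similar half-life.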